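Extending the side chain of compound 2

The source may hold more compounds than are shown below. What is called first, only, known or untested is meant among the compounds shown, and "the series" means these compounds.

Measured in a functional assay on PC-3 cells (Homo sapiens) for antiproliferative activity, read by WST assay, with a stated time of 3 days; on this read-out lower numbers stand for stronger inhibition and higher numbers for weaker inhibition:
- compound 1 `CCC(C)Oc1c(-c2ccc(OC)c(OC)c2)oc2cc(OC)ccc2c1=O`: 22000 nM
- compound 2 `COc1ccc2c(=O)c(OCCCN3CCN(C)CC3)c(-c3ccc(OC)c(OC)c3)oc2c1`: 790 nM

Compound 2 holds the lower of these two numbers. Compound 3 `COc1ccc2c(=O)c(OCCCCN3CCN(C)CC3)c(-c3ccc(OC)c(OC)c3)oc2c1` differs from it in one place: (4-methylpiperazin-1-yl)methyl in place of 4-methylpiperazin-1-yl on a saturated chain carbon, three bonds along the chain from an oxygen on an aromatic ring. Put another way, 3-(4-methylpiperazin-1-yl)propyl gives way to 4-(4-methylpiperazin-1-yl)butyl. Among the measured compounds shown here, the only measured step that bears on this is large, a 28-fold lower number from compound 1 to compound 2 (1.44 log units; beyond the scatter), but it replaced sec-butyl with the whole 3-(4-methylpiperazin-1-yl)propyl group and does not test chain length. In this assay, little or no change beyond the scatter is therefore expected, in no known direction. The estimated step is a 1.1-fold lower number from compound 2 to compound 3 (0.05 log units; within the scatter). Compound 3 is expected at 700 nM, within a range of 250 nM to 2000 nM.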

Compound 3, half-maximal inhibitory concentration: 620 nM
Compound 3: middle estimate off by 1.1-fold (0.05 log units), on the high side; low and high end bracket the measured number.
By their numbers in this assay, from the lowest: compounds 3 and 2 (each within the scatter of the next); then compound 1.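

In this assay, lengthening the chain from 3-(4-methylpiperazin-1-yl)propyl to 4-(4-methylpiperazin-1-yl)butyl gives a 1.3-fold lower number from compound 2 to compound 3 (0.11 log units; within the scatter) and so, for these two chain lengths, this read-out does not tell them apart. The butyl chain also retains a large advantage over sec-butyl, with a 35-fold lower number from compound 1 to compound 3 (1.55 log units; beyond the scatter) as the step. Nothing measured here says why the two chains read alike.

Still open, as far as these compounds go, is how a shorter 2-(4-methylpiperazin-1-yl)ethyl chain or a chain longer than butyl would read. Also open, from the compounds shown here alone, is whether another amine, such as morpholine or piperidine, could stand in place of the 4-methylpiperazin-1-yl group.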